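Allyl for sec-butyl on the amine nitrogen

This account rests on a few compounds, and the source may have more. Where it says the series, first, only, none or still open, it means among the compounds named here.

Of the compounds shown here, three have been read so far in an ADME assay on Caco-2 cells (Homo sapiens) for inhibition, read by sulforhodamine B assay, with a stated time of 72 h; a lower number here means a stronger inhibitor, a higher number a weaker inhibitor. Compound 1 (`COc1cc(/C=C/C(=O)/C=C(/C=C/c2ccc(OC(C)=O)c(OC)c2)NC2CCCCC2)ccc1OC(C)=O`) gives > 25000 nM, which is a limit of the assay. Compound 2 (`CCCNC(=C\C(=O)/C=C/c1ccc(O)c(OC)c1)/C=C/c1ccc(O)c(OC)c1`) gives > 25000 nM, also a limit. Compound 3 (`CCC(C)NC(=C\C(=O)/C=C/c1ccc(O)c(OC)c1)/C=C/c1ccc(O)c(OC)c1`) gives > 25000 nM, again a limit, so compound 3 has no number of its own. For the measured compounds named here, the series so far stands at the limit of > 25000 nM in this assay, at which 3 of the 3 values shown sit.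

Compound 4 (`C=CCNC(=C\C(=O)/C=C/c1ccc(O)c(OC)c1)/C=C/c1ccc(O)c(OC)c1`) carries allyl in place of sec-butyl on an amine nitrogen. Going by the values given here, the one measured step that bears on this change is a step that the two limits leave unreadable from compound 2 to compound 3, on the same amine substituent, and it gives no size to carry over. No direction can be drawn from it, so no step beyond the scatter is expected, and compound 4 is expected to stay close to the limit in this assay. The estimated value for compound 4 is 30000 nM, with an expected range of 12000 nM to 60000 nM. This estimate means an expected step that the limit leaves unreadable from compound 3 to compound 4.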

Compound 4, half-maximal inhibitory concentration: > 25000 nM
Compound 4 was reported as a limit; the forecaster's own chance of this, stated with the estimate: 75%; the middle value is on the limit's open side.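

Compound 4 is reported as a limit in this assay, as are compound 2 and compound 3, so neither step to compound 4 can be read. The compounds shown leave open whether any substituent on the amine nitrogen gives a measurable value rather than a limit in this assay.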